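Replacing the aromatic substituent of compound 3

This account rests on a few compounds, and the source may have more. Where it says the series, first, only, none or still open, it means among the compounds named here.

Measured in a physicochemical assay for solubility, measured as kinetic solubility, at pH 6.5; on this read-out higher numbers stand for higher solubility and lower numbers for lower solubility:
Compound 1 `C[C@@H](c1c[nH]c2ncccc12)c1nnc2ccc(-c3cnn(C)c3)nn12`: 150000 nM
Compound 2 `CN(C)c1ccc2nnc(Cc3ccc4ncccc4c3)n2n1`: 134000 nM
Compound 3 `COc1ccc(-c2ccc3nnc([C@@H](C)c4ccc5ncccc5c4)n3n2)cc1F`: 10900 nM

Compound 3 stands lowest of the three at 10900 nM, beyond the scatter from both others. Compound 4 `C[C@@H](c1ccc2ncccc2c1)c1nnc2ccc(-c3ccc(N(C)C)nc3)nn12` differs from it on an aromatic carbon, with 6-(dimethylamino)pyridin-3-yl in place of 3-fluoro-4-methoxyphenyl on an aromatic carbon. Going by the values given here, compound 2 also carries a dimethylamino group and reads 134000 nM, but no measured pair isolates this change, so the expectation is cautious. A moderate rise beyond the scatter is expected, estimated as a 2.9-fold higher number from compound 3 to compound 4 (0.47 log units; beyond the scatter). For compound 4 the expected value is 32000 nM, with an estimated range from 11000 nM to 95000 nM.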

Compound 4, solubility: 16200 nM
Compound 4: middle estimate off by 2.0-fold (0.30 log units), on the high side; the range from low to high includes it.
By their numbers in this assay, from the lowest: compounds 3 and 4 (each within the scatter of the next); then compounds 2 and 1 (each within the scatter of the next).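

In this assay, going by these compounds alone, 6-(dimethylamino)pyridin-3-yl in place of 3-fluoro-4-methoxyphenyl gives a 1.5-fold higher number from compound 3 to compound 4 (0.17 log units; within the scatter), the first comparison at this position that changes one place only. On this read-out, the two groups cannot be told apart, and the dimethylamino group does not separate compound 4 from compound 3. Nothing at hand explains this result.

The compounds shown do not separate the ring nitrogen from the dimethylamino group, as both enter together. As far as these compounds go, whether a morpholine, a piperazine or a carboxylic acid here would give a step beyond the scatter remains open.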